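The source may hold more compounds than are shown below. What is called first, only, known or untested is meant among the compounds shown, and "the series" means these compounds.

In a physicochemical assay for lipophilicity, measured as octanol-water partition (a higher number here means a more lipophilic compound, a lower number a more polar compound), compound 1 `N#Cc1c(-c2ccco2)[n+]([O-])c2ccc(C(F)(F)F)cc2[n+]1[O-]` gives 1.5. Compound 2 `COc1ccc(-c2c(C#N)[n+]([O-])c3cc(F)ccc3[n+]2[O-])cc1` gives 1.97, the higher of these two numbers, and the gap between them lies beyond the scatter of repeated measurements. Compound 2 is the starting point here. Compound 3 `COc1ccc(-c2c(C#N)[n+]([O-])c3cc(C(F)(F)F)ccc3[n+]2[O-])cc1` differs from it in one place: trifluoromethyl in place of fluoro on an aromatic carbon, which amounts to trifluoromethyl in place of fluoro on an aromatic carbon. Among the measured compounds shown here, no measured pair shows this change on its own, so the expectation rests on the structural change alone and carries a wide margin. A rise beyond the scatter is expected in this assay. The estimated rise is a number 0.53 log units higher from compound 2 to compound 3 (beyond the scatter). Compound 3 is expected at 2.5, with an estimated range from 2.15 to 2.85.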

Compound 3, partition coefficient: 2.45
For compound 3 the middle estimate is 0.05 log units above the measured one; measured number inside the range.
By their numbers in this assay, from the lowest: compound 1; then compound 2; then compound 3.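

The earlier compounds shown here differed in more than one place, so they could not show what a single change does. In this assay, trifluoromethyl in place of fluoro on this aromatic carbon gives a number 0.48 log units higher from compound 2 to compound 3 (beyond the scatter), so this position clearly affects the read-out. A second single change, 4-methoxyphenyl in place of furan-2-yl on an aromatic carbon, gives a number 0.95 log units higher from compound 1 to compound 3 (beyond the scatter), and no measurement offered here explains either step.

Going by these compounds, each change appears only once, so it remains open whether the trifluoromethyl step would be similar with furan-2-yl in place of 4-methoxyphenyl. It is also unknown how the number would move with a different kind of group at this position, such as an amine or a carboxylic acid.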